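A Chloro-to-Trifluoromethyl Swap in a Narrow Series

This account rests on a few compounds, and the source may have more. Where it says the series, first, only, none or still open, it means among the compounds named here.

Of the compounds shown here, three have so far been measured in a functional assay on SR cells (Homo sapiens) for inhibition, read by sulforhodamine B assay, with a stated time of 48 h; a lower number here means a stronger inhibitor of growth, a higher number a weaker inhibitor of growth. Compound 1 (`COc1cc(-c2nn(-c3cccc(NC(=O)c4cccc(C(F)(F)F)c4)c3)cc2-c2ccncc2)ccc1Cl`) gives 838 nM, compound 2 (`COc1cc(-c2nn(-c3cccc(NC(=O)Nc4ccc(Cl)c(Cl)c4)c3)cc2-c2ccncc2)ccc1Cl`) gives 932 nM, and compound 3 (`O=C(Nc1cccc(-n2cc(-c3ccncc3)c(-c3ccc(Cl)c(O)c3)n2)c1)Nc1ccc(Cl)c(Cl)c1`) gives 1140 nM. Compound 3 lies within the usual scatter of both others, so these three numbers cannot be ranked.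

Compound 4 (`O=C(Nc1cccc(-n2cc(-c3ccncc3)c(-c3ccc(Cl)c(O)c3)n2)c1)Nc1ccc(Cl)c(C(F)(F)F)c1`) is compound 3 with trifluoromethyl in place of chloro on an aromatic carbon, ortho to a chloro group and meta to a large group: trifluoromethyl in place of chloro on an aromatic carbon.

Two measured steps offer some guidance, though neither is this exact swap. The closer one is a 1.1-fold higher number from compound 1 to compound 2 (0.05 log units; within the scatter), with (3,4-dichlorophenyl)amino in place of 3-(trifluoromethyl)phenyl on a carbonyl carbon. The other is a 1.2-fold higher number from compound 2 to compound 3 (0.09 log units; within the scatter), with hydrogen in place of methyl on an oxygen on an aromatic ring, a different change from the one at issue here. Both stayed within the scatter, so no step beyond the scatter is expected in this assay for this smaller replacement. The expected change is a 1.1-fold lower number from compound 3 to compound 4 (0.06 log units; within the scatter). For compound 4 the estimated value is 1000 nM, with an expected range from 450 nM to 2200 nM.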

Compound 4, concentration for 50% growth inhibition: 715 nM
Compound 4: middle estimate off by 1.4-fold (0.15 log units), on the high side; the measured number falls inside the stated range.
By their numbers in this assay, from the lowest: compounds 4, 1, 2 and 3 (each within the scatter of the next).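

Compound 3 and compound 4 differ only in a single group on the outer ring, where 3,4-dichlorophenyl becomes 4-chloro-3-(trifluoromethyl)phenyl, and this swap gives a 1.6-fold lower number from compound 3 to compound 4 (0.20 log units; within the scatter) in this assay. Going by these compounds alone, the earlier steps replaced the whole outer part of the molecule or changed the far ring, so this is the first look at this one carbon on its own: chloro, with 1 heavy atom, gives way to trifluoromethyl, with 4 heavy atoms, and the growth-inhibition number does not move beyond the scatter. Nothing measured here explains why the number stays put, and the result says only that this one replacement is tolerated in this one series.

The compounds shown leave open whether a different kind of group on this carbon, such as a nitrile, an amine or a carboxylic acid, would produce a step beyond the scatter. They also leave open whether the chloro that stays on this ring can be exchanged in the same way, and whether the swap holds when the hydroxy group on the other ring is methylated, as it is in compound 2.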